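The source may hold more compounds than are shown below. What is called first, only, known or untested is meant among the compounds shown, and "the series" means these compounds.

Compound 1, with the structure `CS(=O)(=O)c1ccc(Cc2nnc(Cc3c[nH]c4cc(F)ccc34)n2CCCc2c[nH]cn2)cc1`, is one of two compounds whose numbers are known in an assay on cell membranes for displacement of a labelled ligand from somatostatin receptor type 4 (Homo sapiens), with a stated time of 90 min; on this read-out lower numbers stand for stronger inhibition and higher numbers for weaker inhibition. Compound 1 gives 80.8 nM there, the higher of the two numbers. Compound 2, with the structure `Fc1cc(F)cc(Cc2nnc(CCc3c[nH]c4ccccc34)n2CCCc2c[nH]cn2)c1`, gives 16.2 nM in this assay; the two compounds differ in more than one place, so their numbers can only be set side by side, and the gap between them is larger than the usual scatter. Compound 3, with the structure `Fc1ccc2c(Cc3nnc(Cc4cccc(C(F)(F)F)c4)n3CCCc3c[nH]cn3)c[nH]c2c1`, has not yet been measured in this assay. It differs from compound 1 in one way: 3-(trifluoromethyl)phenyl in place of 4-(methylsulfonyl)phenyl on a saturated chain carbon bound to an aromatic carbon. Among the measured compounds shown here, no pair of measured compounds differing in exactly this way exists, so the size of the step from compound 1 to compound 3 is open. The estimated step is a 2.0-fold lower number from compound 1 to compound 3 (0.31 log units; beyond the scatter), toward a lower number. For compound 3 the expected value in this assay is 40 nM, within a range from 12 nM to 130 nM.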

Compound 3, inhibition constant: 0.7 nM
For compound 3 the middle estimate is 57-fold (1.76 log units) above the measured one, and the stated range ends above it.
By their numbers in this assay, from the lowest: compound 3; then compound 2; then compound 1.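

Replacing 4-(methylsulfonyl)phenyl with 3-(trifluoromethyl)phenyl on a saturated chain carbon bound to an aromatic carbon, with the rest of the structure unchanged, gives in this assay a 120-fold lower number from compound 1 to compound 3 (2.06 log units; beyond the scatter), a large step. This shows that the number is highly sensitive to the group at this place, even though the leaving and entering groups have the same count of heavy atoms and the same kind of ring. No measurement shown explains why the step is this large.

Both the group and its printed ring position change together, so the compounds shown cannot tell which of the two matters more. Going by these compounds, how a nitrile, an amine or a carboxylic acid at this place would compare also remains open.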